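Swapping an ester for a methyl ether on the core

The source may hold more compounds than are shown below. What is called first, only, known or untested is meant among the compounds shown, and "the series" means these compounds.

Three measured compounds share one core: compound 1 `CC(C)CC(=O)Oc1ccc2oc(/C=C/[S+](C)[O-])cc(=O)c2c1`, compound 2 `Cc1cccc2c(=O)cc(/C=C/[S+](C)[O-])oc12` and compound 3 `C[S+]([O-])/C=C/c1oc2ccccc2c(=O)c1Cc1ccccc1`. In a functional assay on DLD-1 cells (Homo sapiens) for cytotoxicity, with a stated time of 48 h (on this read-out lower numbers stand for stronger inhibition and higher numbers for weaker inhibition), compound 1 gives 6100 nM, compound 2 gives 6800 nM and compound 3 gives 5100 nM. Compound 1 holds the second highest of these three numbers, yet its gaps to compound 2 and compound 3 both lie within the scatter, so the three cannot be told apart. Compound 4 `COc1ccc2oc(/C=C/[S+](C)[O-])cc(=O)c2c1` is not yet measured. It differs from compound 1 in one place: methyl in place of isobutylcarbonyl on an oxygen on an aromatic ring. Among the compounds with values here, no measured pair shows a step of this kind, so in this assay the change is expected to shift the number by no more than the scatter, in no clear direction. Compound 4 is estimated at 6000 nM, with a range from 2500 nM to 15000 nM. The expected step is a 1.0-fold lower number from compound 1 to compound 4 (0.01 log units; within the scatter).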

Compound 4, half-maximal inhibitory concentration: 5700 nM
Compound 4: the middle estimate sits 1.1-fold (0.02 log units) above what was measured; measured number inside the range.
By their numbers in this assay, from the lowest: compounds 3, 4, 1 and 2 (each within the scatter of the next).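

In this assay, putting methyl in place of isobutylcarbonyl on this oxygen gives a 1.1-fold lower number from compound 1 to compound 4 (0.03 log units; within the scatter). The earlier compounds shown here offered no pair differing in one place, and this one shows that the (isobutylcarbonyl)oxy group can be cut back to methoxy without a readable change in the number. Nothing measured here offers an explanation for this result. Still open, as far as these compounds go, is whether a longer chain ending in an amine or a carboxylic acid on this oxygen would move the number beyond the scatter.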